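Chloro to Ethyl on a Thioamide Capsaicin-Type Antagonist

This account rests on a few compounds, and the source may have more. Where it says the series, first, only, none or still open, it means among the compounds named here.

Compound 2 `CC(C)(C)c1ccc(CCC(=S)NCc2ccc(NS(C)(=O)=O)c(Cl)c2)cc1` gives 96 nM in a functional assay for antagonist activity at transient receptor potential cation channel subfamily V member 1 (Rattus norvegicus); on this read-out lower numbers stand for stronger inhibition and higher numbers for weaker inhibition. Compound 1 `Cc1cc(CNC(=O)CCc2ccc(C(C)(C)C)cc2)cc(Cl)c1NS(C)(=O)=O` is the amide counterpart of compound 2 carrying an extra methyl; in this assay compound 1 gives 100 nM, a number that sits with that of compound 2 within the usual scatter. Compound 3 `CC(C)(C)c1ccc(CCC(=S)NCc2ccc(NS(C)(=O)=O)cc2Cl)cc1` is a positional isomer of compound 2; in this assay compound 3 gives 3500 nM, a much weaker result that lies well beyond the scatter. Compound 4 `CCc1cc(CNC(=S)CCc2ccc(C(C)(C)C)cc2)ccc1NS(C)(=O)=O` differs from compound 2 by ethyl in place of chloro on an aromatic carbon. Going by the values given here, no measured pair shows this exchange, so the size of the step is uncertain; a small shift toward weaker inhibition, possibly not beyond the scatter, is expected. Compound 4 is expected to give about 160 nM, between 45 nM and 600 nM, which means an expected step of a 1.7-fold higher number from compound 2 to compound 4 (0.22 log units; within the scatter).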

Compound 4, half-maximal inhibitory concentration: 240 nM
Compound 4: middle estimate off by 1.5-fold (0.18 log units), on the low side; the measured number falls inside the stated range.
By their numbers in this assay, from the lowest: compounds 2 and 1 (each within the scatter of the next); then compound 4; then compound 3.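

Exchanging chloro for ethyl on this aromatic carbon, ortho to a methanesulfonamido group, gives a 2.5-fold higher number from compound 2 to compound 4 (0.40 log units; beyond the scatter) in this assay on the thioamide series. Going by these compounds alone, this is the first measured exchange at this position, and it shows that ethyl lowers inhibition there modestly without abolishing it. Nothing measured here explains the loss. The compounds shown leave open how bromo, methoxy or a propyl chain on this same carbon would compare with chloro and ethyl. Going by these compounds, whether the exchange gives a similar step on the amide counterpart also remains open.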